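This account rests on a few compounds, and the source may have more. Where it says the series, first, only, none or still open, it means among the compounds named here.

Measured compounds in a functional assay on Hs-578T cells (Homo sapiens) for inhibition, read by sulforhodamine B assay, with a stated time of 48 h, tested at 10 uM; a lower number here means less inhibition, a higher number more inhibition at the concentration tested (going by the name of the read-out):
compound 1, `O=Cc1ccc(-c2cn3ccnc3c(-c3ccc4ncn(C5CCCCC5)c4c3)n2)cc1`, gives 45.5%
compound 2, `c1ccc2c(-c3cn4ccnc4c(-c4ccc5ncn(C6CCCCC6)c5c4)n3)cccc2c1`, gives 3.62%
compound 3, `O=Cc1ccc(-c2cn3ccnc3c(-c3ccc4ncn(Cc5ccccc5)c4c3)n2)cc1`, gives 45.5%

Compound 1 and compound 2 share one core and differ in a single place: naphthalen-1-yl in place of 4-formylphenyl on an aromatic carbon. That change gave a number 41.9 percentage points lower from compound 1 to compound 2 (beyond the scatter). Compound 3 carries a different core; the difference from compound 1 is benzyl in place of cyclohexyl on an aromatic nitrogen, and the values show no change at the digits printed from compound 1 to compound 3 (within the scatter), so compound 1 and compound 3 together stand at the top of the three numbers without being ordered against each other.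

Compound 4, `c1ccc(Cn2cnc3ccc(-c4nc(-c5cccc6ccccc56)cn5ccnc45)cc32)cc1`, has not yet been measured in this assay. It differs from compound 3 by naphthalen-1-yl in place of 4-formylphenyl on an aromatic carbon. The surroundings of the place are described in the same words for both pairs, so this is the same change as that from compound 1 to compound 2. Because the same change gave a number 41.9 percentage points lower from compound 1 to compound 2 (beyond the scatter), and because the core change gave no change at the digits printed from compound 1 to compound 3 (within the scatter), the step for compound 4 is expected to be a number 40.5 percentage points lower from compound 3 to compound 4 (beyond the scatter). Compound 4 is therefore estimated at 5%, with an expected range from 0% to 20%. This rests on a single measured instance of the change; how it behaves on the core of compound 3 is not measured.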

Compound 4, a percentage reported as inhibition, at one concentration (the size of the read-out at that concentration, not a potency): 5.98%
The estimate for compound 4 lay 1 percentage points below the measured number; the range from low to high includes it.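

In this assay, replacing 4-formylphenyl with naphthalen-1-yl on the benzyl-bearing core gave a number 39.5 percentage points lower from compound 3 to compound 4 (beyond the scatter), and this step agrees with the one on the cyclohexyl-bearing core: the same change on two cores in this assay, a number 41.9 percentage points lower (beyond the scatter) from compound 1 to compound 2 and a number 39.5 percentage points lower (beyond the scatter) from compound 3 to compound 4, 2.4 percentage points apart, within the scatter of two such steps

With naphthalen-1-yl in place, benzyl in place of cyclohexyl gave a number 2.4 percentage points higher from compound 2 to compound 4 (within the scatter), matching the result of the same change with 4-formylphenyl: the same change on two cores in this assay, no change at the digits printed (within the scatter) from compound 1 to compound 3 and a number 2.4 percentage points higher (within the scatter) from compound 2 to compound 4, 2.4 percentage points apart, within the scatter of two such steps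

Within the data shown here, the two changes therefore behave independently across these four compounds, but that covers only this pair of aryl groups and this pair of nitrogen substituents at a single concentration in a single cell line, and it does not show that the changes would carry to any other core.

The aryl change alters the formyl group and the ring system together, so the compounds shown do not separate the contribution of the carbonyl from that of the rings. On these data alone, a plain phenyl, or a phenyl carrying a carboxylic acid or an amine in place of the formyl, would bear on this, and a longer chain on the ring nitrogen remains open as well.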